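Replacing a Hydrogen with Methoxy on a Coumarin Lipoic Acid Conjugate

A few compounds are considered here, and "the series" means these few. Any claim that something is new, unique, unknown or untested is made for them only; others in the source may bear on it.

Measured compounds:
Compound 1, `O=C(CCCCC1CCSS1)NCc1cn(CCCOc2ccc3cc(-c4ccccc4)c(=O)oc3c2)nn1`, gives 33.9% in a functional assay on PC-12 cells (Rattus norvegicus) for cytotoxicity, read by MTT assay, with stated times of 3 h and 2 h, tested at 0.1 uM; a lower number here means a weaker effect, a higher number a stronger effect of the compound at the concentration tested.
Compound 2, `COc1ccc(-c2cc3ccc(OCCCn4cc(CNC(=O)CCCCC5CCSS5)nn4)cc3oc2=O)cc1`, gives 42% in this assay.
Compound 3, `O=C(CCCCC1CCSS1)NCc1cn(CCCCOc2ccc3cc(-c4ccccc4)c(=O)oc3c2)nn1`, gives 38.6% in this assay.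

Compound 1 and compound 2 share a core and differ in one place only: methoxy in place of hydrogen on an aromatic carbon. This single change gave a number 8.1 percentage points higher from compound 1 to compound 2 (within the scatter), a step that the usual scatter of this kind of measurement can account for on its own, so the two numbers cannot be told apart with confidence.

Compound 3 carries a different core from compound 1; how the two cores differ is not broken down here. Its number in this assay sits between the other two, and both gaps to it lie within the scatter.

Compound 4, `COc1ccc(-c2cc3ccc(OCCCCn4cc(CNC(=O)CCCCC5CCSS5)nn4)cc3oc2=O)cc1`, is the partner of compound 3 in the same way that compound 2 is the partner of compound 1: it differs from compound 3 by methoxy in place of hydrogen on an aromatic carbon. The place of the change is described in the same words for both pairs, so this is the same change, made twice among the compounds shown.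

Among the measured compounds shown here, with only one measured example of this change, the expectation for compound 4 rests on compound 1 and compound 2 alone, whose step was a number 8.1 percentage points higher from compound 1 to compound 2 (within the scatter). For compound 4 a similar, modest step of a number 6.4 percentage points higher from compound 3 to compound 4 (within the scatter) is expected. Compound 4 is therefore estimated at 45%, within a range of 33% to 57%.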

Compound 4, a percentage reported as activity, at one concentration (the size of the read-out at that concentration, not a potency): 32.1%
Compound 4: middle estimate off by 12.9 percentage points, on the high side, and the stated range ends above it.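

In this assay, going from phenyl to 4-methoxyphenyl on the second core gave a number 6.5 percentage points lower from compound 3 to compound 4 (within the scatter), so this pair, taken alone, cannot be told apart with confidence. Set side by side, the two cases of this one change do not agree with each other, even though neither step stands out by itself: the same change on two cores in this assay, a number 8.1 percentage points higher (within the scatter) from compound 1 to compound 2 and a number 6.5 percentage points lower (within the scatter) from compound 3 to compound 4, 14.6 percentage points apart, beyond the scatter of two such steps. Among the compounds shown here, this shows that the result of the change on one core cannot simply be carried over to the other core, so a step seen on one pair is a poor guide to the next, but it does not show why the two cores part ways, nor that methoxy has a real effect of either sign on either core, and with only two pairs it sets no rule for the series.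

The compounds shown hold only hydrogen or methoxy at this place, so it remains open how a hydroxyl group, a fluorine atom or an amine there would read in this assay. Also open, on these data alone, is whether the disagreement between the two pairs would persist with a longer chain in the linker, or at other tested concentrations.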